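This account rests on a few compounds, and the source may have more. Where it says the series, first, only, none or still open, it means among the compounds named here.

Compound 1 `COc1cc(C(=O)c2cn(-c3ccccc3)cc2-c2ccccc2[N+](=O)[O-])cc(OC)c1OC`: 49 nM
Compound 2 `COc1cc(C(=O)c2cn(-c3ccccc3)cc2-c2cccc([N+](=O)[O-])c2)cc(OC)c1OC`: 50 nM

In a functional assay on MCF7 cells (Homo sapiens) for cytotoxicity, read by MTT assay, with a stated time of 96 h (a lower number here means a stronger inhibitor, a higher number a weaker inhibitor), compound 2 gives 50 nM, and nothing beyond the scatter separates the two measured compounds: a 1.0-fold higher number from compound 1 to compound 2 (0.01 log units; within the scatter). Compound 3 `COc1cc(C(=O)c2cn(-c3cccc(N)c3)cc2-c2cccc([N+](=O)[O-])c2)cc(OC)c1OC` keeps the 3-nitrophenyl group of compound 2 and has amino in place of hydrogen on an aromatic carbon, turning phenyl into 3-aminophenyl: amino in place of hydrogen on an aromatic carbon. For the measured compounds named here, the only measured step, a 1.0-fold higher number from compound 1 to compound 2 (0.01 log units; within the scatter), exchanges 2-nitrophenyl for 3-nitrophenyl and leaves that phenyl untouched, so it bears on this change only indirectly. Going by the values given here, no measured compound carries an amino group, and the data give no direction for the change. Only a small shift is therefore expected, none beyond the scatter: a 1.3-fold lower number from compound 2 to compound 3 (0.10 log units; within the scatter). For compound 3 the estimated value is 40 nM, with an expected range from 10 nM to 150 nM.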

Compound 3, half-maximal inhibitory concentration: 510 nM
The estimate for compound 3 lay 13-fold (1.11 log units) below the measured number; measured number above the stated range.
By their numbers in this assay, from the lowest: compounds 1 and 2 (each within the scatter of the next); then compound 3.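

In this assay the change from phenyl to 3-aminophenyl brings a 10-fold higher number from compound 2 to compound 3 (1.01 log units; beyond the scatter) and so shows that this ring, the same in compound 1 and compound 2, does not accept amino in place of hydrogen without a large change in the number. The earlier step had only exchanged 2-nitrophenyl for 3-nitrophenyl, with nothing beyond the scatter, so this is the first change among the compounds shown to separate one from another. No measurement at hand accounts for the size of this step.

The compounds shown leave open whether a hydroxyl, a methoxy or an acetamide at the same place would give a similar number, or whether the step is specific to the amine. They also leave open whether amino on this ring would have the same effect alongside the 2-nitrophenyl group of compound 1.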